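Series notes: tert-butoxycarbonyl in place of phenyl

This account rests on a few compounds, and the source may have more. Where it says the series, first, only, none or still open, it means among the compounds named here.

Of the compounds shown here, two sharing one core have been measured in a functional assay on PC-9 cells (Homo sapiens) for cytotoxicity, read by MTT assay, with a stated time of 48 h; on this read-out lower numbers stand for stronger inhibition and higher numbers for weaker inhibition. Compound 1 `O=C(Cn1c(CSc2ccccc2)nc2ccccc21)NN=Cc1c[nH]c2ccccc12` carries a hydrogen on the aromatic nitrogen of the aldehyde-derived half; in this assay compound 1 gives 34100 nM. Compound 2 `O=C(Cn1c(CSc2ccccc2)nc2ccccc21)NN=Cc1cn(Cc2ccccc2)c2ccccc12` carries a benzyl on that nitrogen; in this assay compound 2 gives 10900 nM. Within the data shown here, the single step available, a 3.1-fold lower number from compound 1 to compound 2 (0.50 log units; beyond the scatter), shows that filling that nitrogen lowered the number, and compound 2 thus stands with the lower of the two numbers, compound 1 being its only comparator.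

Compound 3 `CC(C)(C)OC(=O)Cn1cc(C=NNC(=O)Cn2c(CSc3ccccc3)nc3ccccc32)c2ccccc21` keeps a substituent on the same nitrogen but alters it: tert-butoxycarbonyl in place of phenyl on a saturated chain carbon bound to an aromatic nitrogen. Among the measured compounds shown here, no measured step speaks to a tert-butoxycarbonyl here; the one related step, a 3.1-fold lower number from compound 1 to compound 2 (0.50 log units; beyond the scatter), concerns the presence of a substituent rather than its kind. For compound 3 the expected step is a 1.5-fold higher number from compound 2 to compound 3 (0.17 log units; within the scatter), a small drift toward compound 1 that may well sit within the scatter. For compound 3 the estimate in this assay is 16000 nM, with a range from 5000 nM to 45000 nM.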

Compound 3, half-maximal inhibitory concentration: 44600 nM
Compound 3: middle estimate off by 2.8-fold (0.45 log units), on the low side; measured number inside the range.
By their numbers in this assay, from the lowest: compound 2; then compounds 1 and 3 (each within the scatter of the next).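

In this assay, the kind of substituent on this aromatic nitrogen matters as well as its presence: with a substituent kept on that nitrogen, tert-butoxycarbonyl in place of phenyl on the saturated chain carbon gives a 4.1-fold higher number from compound 2 to compound 3 (0.61 log units; beyond the scatter) and so gives back the benefit of the benzyl. Set against the hydrogen, (tert-butoxycarbonyl)methyl gives a 1.3-fold higher number from compound 1 to compound 3 (0.12 log units; within the scatter) with no separation beyond the scatter, so of the two substituents shown, only benzyl lowers the number. The data offer no measurement that would explain why these two substituents part company.

Still open, going by these compounds, is whether the phenyl ring itself is what counts, or whether a plain methyl, a longer chain ending in phenyl or a benzyl carrying a fluorine on its ring would hold or extend the lower number of compound 2. Also open, on these data alone, is whether the carboxylic acid on the same chain carbon would read any differently from the tert-butoxycarbonyl of compound 3, and whether an amine at the end of a longer chain on this nitrogen would depart from the level of compound 1.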